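Methyl for Ethoxy on a Weakly Cytotoxic Benzothiazolyl Thiourea

A few compounds are considered here, and "the series" means these few. Any claim that something is new, unique, unknown or untested is made for them only; others in the source may bear on it.

Of the compounds shown here, three have so far been measured in a functional assay on B16-F10 cells (Mus musculus) for cytotoxicity, read by MTT assay, with a stated time of 48 h; a higher number here means a weaker inhibitor, a lower number a stronger inhibitor. Compound 1 `Clc1cccc2sc(Nc3nc4ccccc4s3)nc12` gives 29500 nM in this assay. Compound 3 `CCOc1ccc2nc(Nc3nc4ccccc4s3)sc2c1` does not reach a number in this assay; it stops at a limit, > 50000 nM. Compound 2 `CCOc1ccc2nc(NC(=S)Nc3ccccc3)sc2c1` likewise stops at a limit in this assay, > 50000 nM, so only an upper bound on its potency is known. Among the numbers shown, compound 2 thus stands with compound 3 at the limit of > 50000 nM in this assay, at which 2 of the 3 values shown sit, and no step between two measured compounds that differ in a single place is available to guide the next move.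

Compound 4 `Cc1ccc2nc(NC(=S)Nc3ccccc3)sc2c1` has not yet been measured. It differs from compound 2 in one place: methyl in place of ethoxy on an aromatic carbon. Within the data shown here, because the only values at hand for compound 2 and compound 3 sit at the limit of > 50000 nM in this assay, at which 2 of the 3 values shown sit, and the structural change is a small one on the aromatic ring, no step beyond the usual scatter is expected from compound 2 to compound 4 in this assay, and the expected step that the limit leaves unreadable from compound 2 to compound 4 is set accordingly. For compound 4 the estimated value in this assay is 60000 nM, with a likely range from 20000 nM to 200000 nM, and a fair chance that this assay again reports only a limit.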

Compound 4, half-maximal inhibitory concentration: > 50000 nM
Compound 4 gave a limit, no number; the forecaster's own chance of this, stated with the estimate: 65%; the middle value is on the limit's open side.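

Compound 2 and compound 4 each stop at a limit in this assay, so no step can be read for methyl in place of ethoxy on an aromatic carbon. The compounds shown leave open how far either compound lies from that limit, and whether this change alters cytotoxicity on these cells at all.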